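Methoxy step from compound 1 to compound 4

The compounds below may be only part of what the source reports. "The series", "measured", "known", "first", "only" and "open" are said of these compounds alone.

The series is followed in a functional assay on HepG2 cells (Homo sapiens) for cytotoxicity, read by MTT assay, with a stated time of 48 h; a higher number here means a weaker inhibitor, a lower number a stronger inhibitor. Compound 1 `O=C(CSc1nc2ccc(NC(=O)c3ccccc3)cc2s1)NCc1ccc(Cl)cc1` gives 30100 nM. Compound 2 `CNC(=O)CSc1nc2ccc(NC(=O)c3ccccc3)cc2s1` gives 26500 nM, and compound 3 `O=C(CSc1nc2ccc(NC(=O)c3ccccc3)cc2s1)NCc1ccccc1` gives 34200 nM. Among these three numbers compound 1 stands second highest, nearest to compound 2 and furthest from compound 3, and all three lie within the scatter of one another: a 1.1-fold lower number from compound 1 to compound 2 (0.06 log units; within the scatter), a 1.1-fold higher number from compound 1 to compound 3 (0.06 log units; within the scatter), a 1.3-fold higher number from compound 2 to compound 3 (0.11 log units; within the scatter). Compound 4 `COc1ccccc1C(=O)Nc1ccc2nc(SCC(=O)NCc3ccc(Cl)cc3)sc2c1` differs from compound 1 by methoxy in place of hydrogen on an aromatic carbon. Among the measured compounds shown here, none of the measured steps touches the benzamido side of the shared core; all three concern the chain on the amide nitrogen and the chloro on its aryl group, and each is within the scatter. For the measured compounds named here, with no measured step on the changed side and no movement beyond the scatter anywhere in the set, no step beyond the scatter is expected in this assay from compound 1 to compound 4, in either direction. Compound 4 is therefore estimated at 30000 nM, with a range of 12000 nM to 75000 nM, which corresponds to an expected step of a 1.0-fold lower number from compound 1 to compound 4 (0.00 log units; within the scatter).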

Compound 4, half-maximal inhibitory concentration: 600 nM
Beside the measured number, compound 4's estimate is 50-fold (1.70 log units) above it, and the stated range ends above it.
By their numbers in this assay, from the lowest: compound 4; then compounds 2, 1 and 3 (each within the scatter of the next).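

In this assay, among the compounds shown here, the benzamido side of the shared core responds where the earlier changes did not: methoxy in place of hydrogen on an aromatic carbon, ortho to a large group, gives a 50-fold lower number from compound 1 to compound 4 (1.70 log units; beyond the scatter) as the only step in the set beyond the scatter, while a 1.1-fold lower number from compound 1 to compound 2 (0.06 log units; within the scatter) and a 1.1-fold higher number from compound 1 to compound 3 (0.06 log units; within the scatter) on the other side of compound 1 both stay within it. The entering group counts 2 heavy atoms, so a change of this size at this position can move the number strongly in this series. No measurement bears on why the step is so large.

On these data alone, whether the step belongs to methoxy itself stays open, and a hydroxy, fluoro or ethoxy group on the same carbon would test that. As far as these compounds go, whether it carries over to the chains of compound 2 and compound 3 also stays open.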